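Sugar-ring truncation in an acetylated C-glycoside chalcone series

A few compounds are considered here, and "the series" means these few. Any claim that something is new, unique, unknown or untested is made for them only; others in the source may bear on it.

Measured compounds:
compound 1 `CC(=O)OC[C@H]1O[C@@H](CC(=O)/C=C/c2cccc(NC(=O)Nc3ccccc3)c2)[C@H](OC(C)=O)[C@@H](OC(C)=O)[C@@H]1OC(C)=O` with 180000 nM in an ADME assay on Vero cells (Chlorocebus sabaeus) for cytotoxicity, read by resazurin assay, with a stated time of 2 days; a lower number here means that less compound is tolerated, a higher number that more compound is tolerated
compound 2 `CC(=O)OC[C@H]1O[C@@H](CC(=O)/C=C/c2cccc(NS(=O)(=O)c3ccc(C)cc3)c2)[C@H](OC(C)=O)[C@@H](OC(C)=O)[C@@H]1OC(C)=O` with 584000 nM in this assay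
compound 3 `CC(=O)OC[C@H]1O[C@@H](CC(=O)/C=C/c2cccc(NC(=S)Nc3ccccc3)c2)[C@H](OC(C)=O)[C@@H](OC(C)=O)[C@@H]1OC(C)=O` with 337000 nM in this assay

Compound 2 gives the highest of the three numbers in this assay. Against compound 3 the gap is a 1.7-fold lower number from compound 2 to compound 3 (0.24 log units; within the scatter), so the two cannot be told apart. Against compound 1 the gap is a 3.2-fold higher number from compound 1 to compound 2 (0.51 log units; beyond the scatter), the only step of the three that stands beyond the scatter; the third step, a 1.9-fold higher number from compound 1 to compound 3 (0.27 log units; within the scatter), is within it.

Compound 4 `CC(=O)O[C@@H]1[C@@H](OC(C)=O)[C@H](OC(C)=O)CO[C@H]1CC(=O)/C=C/c1cccc(NS(=O)(=O)c2ccc(C)cc2)c1` differs from compound 2 by hydrogen in place of acetoxymethyl on a saturated ring carbon. Going by the values given here, every measured step concerns the substituent on the aromatic nitrogen; no measured pair varies the acetylated ring, so no step bears on this change. The shared core and the sulfonamide of compound 2 are kept. With nothing to build on, the expectation is a step no larger than the scatter, a 1.1-fold lower number from compound 2 to compound 4 (0.03 log units; within the scatter). Compound 4 is estimated at 550000 nM, within 250000 nM to 1200000 nM.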

Compound 4, half-maximal cytotoxic concentration: 268000 nM
Estimate against measurement, compound 4: 2.1-fold (0.31 log units) above; the range from low to high includes it.
By their numbers in this assay, from the lowest: compounds 1, 4, 3 and 2 (each within the scatter of the next, the first and the last beyond it).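

In this assay, going by these compounds alone, this is the first step that touches the acetylated ring rather than the substituent on the aromatic nitrogen: hydrogen in place of acetoxymethyl gives a 2.2-fold lower number from compound 2 to compound 4 (0.34 log units; beyond the scatter), a modest change. The saturated ring carbon next to the ring oxygen is therefore a position where a change can be read in this assay, and here removing acetoxymethyl goes with less compound being tolerated. Nothing available accounts for this step, so its cause remains unknown.

The ring change is shown only with the sulfonamide of compound 2, so whether it carries over to the phenylcarbamoyl group of compound 1 remains open. Also open, as far as these compounds go, is how a hydroxymethyl, a methyl or a carboxylic acid on this ring carbon would compare with acetoxymethyl and hydrogen.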